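The source may report more compounds than this note shows. Statements on the series, on what has been measured and on what is new or still open speak of the compounds shown alone.

Series notes on an assay on DDT1 cells (Cricetulus griseus) for binding affinity to adenosine receptor A1 (Homo sapiens), read by radioligand binding (a lower number here means a stronger inhibitor, a higher number a weaker inhibitor), three compounds measured and one to come.

Compound 3 `O=C(NC1CCCCC1)OC[C@H]1OC(n2cnc3c(NC4CCOC4)ncnc32)[C@H](O)[C@@H]1O` gives 584 nM and stands highest of the three numbers: compound 2 `O[C@@H]1[C@@H](CO/C(S)=N/C2CCCC2)OC(n2cnc3c(NC4CCOC4)ncnc32)[C@@H]1O` gives 72 nM, and compound 1 `CC/N=C(\S)OC[C@H]1OC(n2cnc3c(NC4CCOC4)ncnc32)[C@H](O)[C@@H]1O` gives 33 nM.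

Compound 4 `CN(C)C(=S)OC[C@H]1OC(n2cnc3c(NC4CCOC4)ncnc32)[C@H](O)[C@@H]1O` differs from compound 3 by a group of 5 heavy atoms (3 carbon, 1 nitrogen, 1 sulfur; no ring) in place of a group of 9 heavy atoms (7 carbon, 1 nitrogen, 1 oxygen; one six-membered non-aromatic ring of carbon only), on an oxygen on a saturated carbon; the entering group has no common name.

Among the measured compounds shown here, two measured steps bear on this change. Going the other way, from a small sulfur-bearing group without a ring to the cyclohexylcarbamoyl group, was an 18-fold higher number from compound 1 to compound 3 (1.25 log units; beyond the scatter), and from the cyclopentyl-bearing sulfur group to cyclohexylcarbamoyl was an 8.1-fold higher number from compound 2 to compound 3 (0.91 log units; beyond the scatter). Both put the cyclohexylcarbamoyl group at the weak end. Among the sulfur-bearing groups themselves, a 2.2-fold higher number from compound 1 to compound 2 (0.34 log units; beyond the scatter) was the only gap, small next to the others. The change to compound 4 returns to a sulfur-bearing group of the same heavy-atom count as that of compound 1, though not the same group, so a large step down in this assay is expected, with some allowance for the group being new to the series.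

Compound 4 is therefore expected at 50 nM in this assay, in the range 15 nM to 170 nM, which means an expected step of a 12-fold lower number from compound 3 to compound 4 (1.07 log units; beyond the scatter).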

Compound 4, inhibition constant: 205 nM
Compound 4: middle estimate off by 4.1-fold (0.61 log units), on the low side; the measured number lies above the stated range.
By their numbers in this assay, from the lowest: compound 1; then compound 2; then compound 4; then compound 3.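

In this assay leaving the cyclohexylcarbamoyl group gives only a 2.8-fold lower number from compound 3 to compound 4 (0.45 log units; beyond the scatter) and so recovers part of the earlier gap, while a 6.2-fold higher number from compound 1 to compound 4 (0.79 log units; beyond the scatter) separates two groups of the same heavy-atom count and the same atoms on the same oxygen on a saturated carbon. Heavy-atom count therefore does not order this position, and a sulfur-bearing group alone does not secure the low end of the series: a 2.8-fold higher number from compound 2 to compound 4 (0.45 log units; beyond the scatter) places the smaller group of compound 4 on the weaker side of the cyclopentyl-bearing group, with compound 4 standing between compound 2 and compound 3. The gap between the two groups of equal size remains unexplained. No supporting data accompany these numbers.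

The compounds shown leave open how much of the separation from compound 3 belongs to the sulfur and how much to the ring, a question that a pairing of ethylcarbamoyl with compound 1 or of dimethylcarbamoyl with compound 4 would address. Also open, on these data alone, is how a cyclohexyl group carried on the sulfur-bearing group of compound 2 would compare with the cyclopentyl group there.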